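This account rests on a few compounds, and the source may have more. Where it says the series, first, only, none or still open, it means among the compounds named here.

In a functional assay on A549 cells (Homo sapiens) for inhibition, read by MTT assay, with a stated time of 24 h (a higher number here means a weaker inhibitor, a lower number a stronger inhibitor), three compounds on a shared core have been measured. Compound 1 `CC1(C)[C@H]2CC[C@]1(C)N(Cc1cn(-c3ccc(F)cc3)nn1)C(=O)C2` reads 230 nM and compound 2 `Cc1ccc(-n2cc(CN3C(=O)C[C@@H]4CC[C@@]3(C)C4(C)C)nn2)cc1` reads 400 nM on this scale, while compound 3 `CC1(C)[C@H]2CC[C@]1(C)N(Cc1cn(-c3cccc(O)c3)nn1)C(=O)C2` reads 180 nM on the same scale. Among the measured compounds shown here, compound 3 therefore stands clear of only one neighbour: the step of a 1.3-fold lower number from compound 1 to compound 3 (0.11 log units; within the scatter) stays within the scatter, and only the step of a 2.2-fold lower number from compound 2 to compound 3 (0.35 log units; beyond the scatter) goes beyond it, modestly so. Compound 4 `Cc1cccc(-n2cc(CN3C(=O)C[C@@H]4CC[C@@]3(C)C4(C)C)nn2)c1` is still unmeasured. It keeps the core but has methyl in place of hydroxy on an aromatic carbon, meta to a large group (methyl in place of hydroxy on an aromatic carbon), so that 3-hydroxyphenyl becomes 3-methylphenyl. For the measured compounds named here, no measured compound carries 3-methylphenyl. The closest evidence is the exchange of 4-methylphenyl and 3-hydroxyphenyl in the step of a 2.2-fold lower number from compound 2 to compound 3 (0.35 log units; beyond the scatter) which, read backwards, points to a higher number for a methyl compound, although the methyl of compound 2 sits in 4-methylphenyl instead. The step of a 1.7-fold higher number from compound 1 to compound 2 (0.24 log units; within the scatter) adds little, as it stays within the scatter. A small rise is therefore expected, and the estimated step of a 1.7-fold higher number from compound 3 to compound 4 (0.22 log units; within the scatter) may not clear the scatter. Compound 4 is expected at about 300 nM with an estimated range from 130 nM to 650 nM as the likely span.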

Compound 4, half-maximal inhibitory concentration: 50 nM
Compound 4: the middle estimate sits 6.0-fold (0.78 log units) above what was measured; the measured number lies below the stated range.
By their numbers in this assay, from the lowest: compound 4; then compounds 3, 1 and 2 (each within the scatter of the next, the first and the last beyond it).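

In this assay, among the compounds shown here, methyl in place of hydroxy gives a 3.6-fold lower number from compound 3 to compound 4 (0.56 log units; beyond the scatter) and so shows that the hydroxy on this aromatic carbon, meta to a large group, is not required for a low number here, as the earlier compounds could not show. Moving to 3-methylphenyl from 4-methylphenyl gives an 8.0-fold lower number from compound 2 to compound 4 (0.90 log units; beyond the scatter) and shows for the first time that, with methyl on both rings, the number depends on where that methyl stands. Replacing 4-fluorophenyl with 3-methylphenyl gives a 4.6-fold lower number from compound 1 to compound 4 (0.66 log units; beyond the scatter) and leaves compound 4 as the strongest inhibitor of the four, clear of the scatter against each of the other three, whereas compound 3 had stood clear of only compound 2.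

No supporting measurement is available to explain why methyl gives this result. It remains open whether ethyl, methoxy, chloro or an amine on the same aromatic carbon would keep the number this low, and whether the order of these compounds would hold on other cell lines or after a different exposure time.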